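Cytotoxicity in This Series: From Compound 3 to Compound 4

A few compounds are considered here, and "the series" means these few. Any claim that something is new, unique, unknown or untested is made for them only; others in the source may bear on it.

Three compounds sharing one core were examined in a toxicity assay on MDCK cells (Canis lupus familiaris) for cytotoxicity, read by crystal violet staining, with a stated time of 48 h; on this read-out lower numbers stand for higher toxicity in this test and higher numbers for lower toxicity in this test. Compound 1 `Cc1ccc2cc(CN(Cc3ccc(C(C)C)cc3)Cc3ccccc3F)c(=O)[nH]c2c1` gave only a limit, > 33000 nM. Compound 2 `Cc1ccc2cc(CN(Cc3ccc(C(C)(C)C)cc3)C3CCCC3)c(=O)[nH]c2c1` also gave only a limit, > 10000 nM. Compound 3 `Cc1ccc2[nH]c(=O)c(CN(Cc3ccc(OCC(=O)OC(C)(C)C)cc3)Cc3ccc(C(C)(C)C)cc3)cc2c1` likewise reached only a limit, > 10000 nM. So compound 3 stands at a limit, and the other two values shown are limits as well (the limit of > 10000 nM in this assay, at which 2 of the 3 values shown sit; (the limit of > 33000 nM in this assay, at which 1 of the 3 values shown sits)). Going by the values given here, no step between measured compounds is available; every value is a limit. Compound 4 `CSc1ccc(CN(Cc2ccc(C(C)(C)C)cc2)Cc2cc3cc(C)ccc3[nH]c2=O)cc1` has not yet been measured and differs from compound 3 by methylsulfanyl in place of (tert-butoxycarbonyl)methoxy on an aromatic carbon. The step that the limit leaves unreadable from compound 3 to compound 4 is expected to stay within the scatter, with compound 4 again probably reported only as a limit. Compound 4 is estimated at 30000 nM, with a range from 10000 nM to 100000 nM.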

Compound 4, half-maximal cytotoxic concentration: > 5000 nM
Compound 4 gave a limit, no number; the forecaster's own chance of this, stated with the estimate: 80%; the middle value does not contradict the limit.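

Going by these compounds alone, compound 3 and compound 4 each gave only a limit in this assay, and no step between them can be read. The compounds shown leave open the actual half-maximal cytotoxic concentration of each one.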